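A few compounds are considered here, and "the series" means these few. Any claim that something is new, unique, unknown or untested is made for them only; others in the source may bear on it.

Measured compounds, with their values in a physicochemical assay for lipophilicity; a lower number here means a more polar compound, a higher number a more lipophilic compound:

compound 1, `CC(=O)OCc1ccc([N+](=O)[O-])cc1`: 2.02
compound 2, `CC(=O)OCc1ccc(OC(C)=O)cc1`: 2.03
compound 3, `O=C(OCc1ccc([N+](=O)[O-])cc1)c1cnc2ccccc2n1`: 2.27

Compound 1 and compound 2 differ in one place: acetoxy in place of nitro on an aromatic carbon. In this assay the step is a number 0.01 log units higher from compound 1 to compound 2 (within the scatter), so the two numbers cannot be told apart.

Compound 3 carries a different core; the difference between its core and the core of compound 1 is not broken down here. Going by the values given here, its value in this assay lies within the scatter of the values of compound 1 and of compound 2, and no single-point step connects it to either, so only the bare numbers can be compared.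

Compound 4, `CC(=O)Oc1ccc(COC(=O)c2cnc3ccccc3n2)cc1`, is not yet measured. It differs from compound 3 as acetoxy in place of nitro on an aromatic carbon. Among the compounds with values here, this is the same kind of change as the one from compound 1 to compound 2; the surroundings differ only in that the group is para to a large group in compound 3 and para to a group of 5 heavy atoms in compound 1.

Beside a number 0.01 log units higher from compound 1 to compound 2 (within the scatter), the step from compound 3 to compound 4 in this assay is expected to be a number 0.01 log units higher from compound 3 to compound 4 (within the scatter), resting on the one measured instance of the change, compound 1 to compound 2. For compound 4 the expected value in this assay is 2.28, with an estimated range from 1.9 to 2.65.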

Compound 4, partition coefficient: 2.15
Estimate against measurement, compound 4: 0.13 log units above; the measured number falls inside the stated range.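

In this assay, acetoxy in place of nitro on an aromatic carbon gives a number 0.12 log units lower from compound 3 to compound 4 (within the scatter) on this core, while on the core of compound 1 it gave a number 0.01 log units higher from compound 1 to compound 2 (within the scatter) for the same change. Going by these compounds alone, both steps lie within the scatter, so on these two cores the change can be carried across with no step that stands clear of repeat measurement, and the numbers in each pair cannot be told apart. Within the data shown here, this does not fix a size or a direction for the change, it rests on only two pairs and so does not show that the change would stay within the scatter on any further core, and nothing at hand bears on why the values fall as they do.

The compounds shown leave open whether another group at the same place, such as an amine, a carboxylic acid or a longer chain, would give a step in this assay that stands beyond the scatter on either core. Also open, going by these compounds, is how the nitro and acetoxy pair behaves on cores other than these two, and what the difference between the two cores itself contributes.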